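A few compounds are considered here, and "the series" means these few. Any claim that something is new, unique, unknown or untested is made for them only; others in the source may bear on it.

Working notes on the series, values from a functional assay on MCF7 cells (Homo sapiens) for cytotoxicity, read by sulforhodamine B assay, with a stated time of 48 h; a lower number here means a stronger inhibitor, a higher number a weaker inhibitor:

- compound 1 `O=C(/C=C/c1ccc(Br)cc1)c1cccc(-c2cccc(F)c2)c1`: 18300 nM
- compound 2 `COc1cccc(/C=C/C(=O)c2cccc(-c3cccc(F)c3)c2)c1OC`: 11700 nM
- compound 3 `COc1ccc(-c2cc(C(=O)/C=C/c3cccc(OC)c3OC)ccc2N)cc1OC`: 10200 nM

Compound 1, at 18300 nM, lies within the scatter of both compound 2 and compound 3, so these values give no ranking. Among the compounds with values here, no pair of measured compounds differs in one place, so no measured step isolates the next change.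

Compound 4 `COc1ccc(/C=C/C(=O)c2cccc(-c3cccc(F)c3)c2)cc1` is the next compound to be read. Relative to compound 1, it has methoxy in place of bromo on an aromatic carbon, para to a large group: methoxy in place of bromo on an aromatic carbon. Within the data shown here, the only guide is indirect: compound 2, which also carries methoxy groups, gives 11700 nM, within the scatter of compound 1. No step beyond the scatter is therefore expected, and no direction can be assigned with confidence.

The expected 1.3-fold lower number from compound 1 to compound 4 (0.12 log units; within the scatter) stays within the scatter. For compound 4 the estimated value is 14000 nM, with an expected range of 7000 nM to 28000 nM.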

Compound 4, half-maximal inhibitory concentration: 3080 nM
Compound 4: middle estimate off by 4.5-fold (0.66 log units), on the high side, outside the stated range (below it).
By their numbers in this assay, from the lowest: compound 4; then compounds 3, 2 and 1 (each within the scatter of the next).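

In this assay, within the data shown here, the exchange of 4-bromophenyl to 4-methoxyphenyl gives a 5.9-fold lower number from compound 1 to compound 4 (0.77 log units; beyond the scatter) and so provides the first single-place comparison. The earlier compounds shown here, with no such pair among them, could not show that the substituent on this aromatic carbon, para to a large group, can move the value beyond the scatter. The step is a single pair on the core of compound 1, and no measurement shown accounts for it.

From the compounds shown here alone, whether a hydroxyl, a chloro group or a longer alkoxy chain at this position would follow methoxy or bromo remains open. Also open, going by these compounds, is whether the same exchange would produce a step of similar size on a core carrying different groups elsewhere.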